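Replacing the diethylcarbamoyl of compound 2 with an isoxazole

This account rests on a few compounds, and the source may have more. Where it says the series, first, only, none or still open, it means among the compounds named here.

Compound 2 `CCN(CC)C(=O)[C@@H]1CCCN(S(=O)(=O)c2ccc(S(=O)(=O)N(CC)CC)cc2)C1` gives in a functional assay on MIA PaCa-2 cells (Homo sapiens) for inhibition, read by MTT assay, with a stated time of 3 days (a lower number here means a stronger inhibitor, a higher number a weaker inhibitor), only a limit, > 10000 nM. Compound 1 `CCN(CC)S(=O)(=O)c1ccc(S(=O)(=O)N2CCC[C@@H](C(=O)NC3CN(C(=O)C4CC4)C3)C2)cc1` likewise gives in this assay a limit, > 10000 nM. Compound 3 `CCN(CC)S(=O)(=O)c1ccc(S(=O)(=O)N2CCC[C@@H](C(=O)N3CCN(c4nc(C)no4)CC3)C2)cc1` also gives in this assay a limit, > 10000 nM. All three sit at the limit of > 10000 nM in this assay, at which 3 of the 3 values shown sit, so the steps a step that the two limits leave unreadable from compound 1 to compound 2, a step that the two limits leave unreadable from compound 1 to compound 3 and a step that the two limits leave unreadable from compound 2 to compound 3 cannot be read. Compound 4 `CCN(CC)S(=O)(=O)c1ccc(S(=O)(=O)N2CCC[C@@H](c3cc(C)no3)C2)cc1` differs from compound 2 by 3-methyl-1,2-oxazol-5-yl in place of diethylcarbamoyl on a saturated ring carbon. Among the compounds with values here, none of the measured steps exchanges a carbonyl-bearing group for an aromatic ring on the saturated ring carbon, so no measured step bears directly on this change. Given (the limit of > 10000 nM in this assay, at which 3 of the 3 values shown sit), compound 4 is expected to stay near that limit. The estimated step is a step that the limit leaves unreadable from compound 2 to compound 4. The estimate for compound 4 in this assay is 15000 nM, within 3000 nM to 60000 nM.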

Compound 4, half-maximal inhibitory concentration: > 10000 nM
Compound 4 ended at the assay's limit (the forecaster's own chance of this, stated with the estimate: 85%); the middle value does not contradict the limit.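

Compound 4 gives only a limit, > 10000 nM. Compound 2 also gives only a limit, so the step between them cannot be read.

The compounds shown leave open how any of these groups affects inhibition, with every value resting on the same limit: the limit of > 10000 nM in this assay, at which 4 of the 4 values shown sit.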